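The source may hold more compounds than are shown below. What is called first, only, known or untested is meant among the compounds shown, and "the series" means these compounds.

Three compounds share one core and differ only in the group on a carbonyl carbon. In an ADME assay on microsomes from liver (Mus musculus) for metabolic stability, read by LC-MS, with a stated time of 30 min, tested at 1 uM (on this read-out higher numbers stand for a more stable compound and lower numbers for a less stable compound), compound 1 `CC(=O)N1CCN(C(=O)[C@@H]2CC[C@@H](C)N2C(=O)C2=C(C(C)C)N3C(=N[C@@](C)(c4ccc(Cl)cc4)[C@H]3c3ccc(Cl)cc3)S2)CC1` gives 13%, compound 2 `CC(=O)N1CCN(C(=O)[C@@H]2CC[C@@H](C)N2C(=O)C2=C(C(C)C)N3C(=N[C@@](C)(c4ccc(Cl)cc4)[C@H]3c3ccc(Cl)cc3)S2)C[C@H]1C` gives 55% and compound 3 `CC(=O)N1CCN(C(=O)[C@@H]2CC[C@@H](C)N2C(=O)C2=C(C(C)C)N3C(=N[C@@](C)(c4ccc(Cl)cc4)[C@H]3c3ccc(Cl)cc3)S2)C[C@@H]1C` gives 65%. Two steps fix where compound 3 stands: it is clear of compound 1 by a number 52 percentage points higher from compound 1 to compound 3 (beyond the scatter), but it cannot be separated from compound 2, as the step is a number 10 percentage points higher from compound 2 to compound 3 (within the scatter).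

Compound 4 `CC(C)C1=C(C(=O)N2[C@H](C)CC[C@H]2C(=O)N2CCN(C)C(C)(C)C2)SC2=N[C@@](C)(c3ccc(Cl)cc3)[C@@H](c3ccc(Cl)cc3)N21` changes that same group: a group of 9 heavy atoms (7 carbon, 2 nitrogen; one six-membered non-aromatic ring with 2 hetero atoms) in place of a group of 10 heavy atoms (7 carbon, 2 nitrogen, 1 oxygen; one six-membered non-aromatic ring with 2 hetero atoms), on a carbonyl carbon. The nearest evidence comes from two large steps in this group, a number 42 percentage points higher from compound 1 to compound 2 (beyond the scatter) and a number 52 percentage points higher from compound 1 to compound 3 (beyond the scatter), each a methyl in place of hydrogen on a saturated ring carbon. They show that this assay responds strongly to small edits here. However, no measured pair replaces the whole group, so they give no firm direction. The low value of compound 1 at 13% shows how much can be lost in this part of the structure, so some risk lies on the downward side. The expected change is therefore a moderate fall, estimated as a number 15 percentage points lower from compound 3 to compound 4 (beyond the scatter). For compound 4 the estimated value is 50%, with an expected range from 25% to 75%.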

Compound 4, percent of the compound remaining: 84%
The estimate for compound 4 lay 34 percentage points below the measured number; measured number outside the range, above it.
By their numbers in this assay, from the lowest: compound 1; then compounds 2 and 3 (each within the scatter of the next); then compound 4.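

In this assay the replacement of the whole group on a carbonyl carbon, which the earlier methyl steps did not cover, moves the number upward each time: a number 19 percentage points higher from compound 3 to compound 4 (beyond the scatter), a number 29 percentage points higher from compound 2 to compound 4 (beyond the scatter) and a number 71 percentage points higher from compound 1 to compound 4 (beyond the scatter). Compound 4 therefore stands highest of the four, which shows that a group of 9 heavy atoms (7 carbon, 2 nitrogen; one six-membered non-aromatic ring with 2 hetero atoms), with no defined stereocentre, can go further at this place than the methyl steps alone did. The earlier compounds gave no reading on whether configuration in this group matters, since their two numbers lie within the scatter of each other, and that reading rests on a single pair: the fact that compounds 2 and 3 differ only in the configuration as drawn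

The compounds shown change several features of the group at once, and they do not tell which of these features carries the rise. As far as these compounds go, it also stays open how a carboxylic acid or a longer chain on this carbonyl carbon would read in this assay.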